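Group exchange on the carbonyl: compound 2 to compound 3

The source may hold more compounds than are shown below. What is called first, only, known or untested is meant among the compounds shown, and "the series" means these compounds.

In an ADME assay on microsomes from liver (Homo sapiens) for metabolic stability, read by LC-MS, with a stated time of 30 min, tested at 1 uM (a lower number here means that less of the compound is left, a higher number that more of the compound is left), compound 1 `Cc1ccccc1S(=O)(=O)c1ccc(CNC(=O)c2cc3cnccc3[nH]2)cc1` gives 48%. In the same read-out compound 2 `O=C(NCc1ccc(S(=O)(=O)N2CCCCC2)cc1)c1cc2cnccc2o1` gives 46%. These two values lie within the usual scatter of each other, so compound 2 stands level with compound 1 and no order can be read from them. Within the data shown here, the two compounds differ in more than one place, so no measured step is available as a guide.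

Compound 3 `O=C(NCc1ccc(S(=O)(=O)N2CCCCC2)cc1)c1ccn2cncc2c1` keeps the rest of compound 2 and changes only the group on the carbonyl carbon, whose other neighbour is the amide-type nitrogen: a group of 9 heavy atoms (7 carbon, 2 nitrogen; one five-membered aromatic ring with 2 hetero atoms, one six-membered aromatic ring with 1 hetero atom) in place of a group of 9 heavy atoms (7 carbon, 1 nitrogen, 1 oxygen; one five-membered aromatic ring with 1 hetero atom, one six-membered aromatic ring with 1 hetero atom), on a carbonyl carbon. Both groups carry one five-membered aromatic ring and one six-membered aromatic ring.

Among the measured compounds shown here, with no measured precedent for this exchange, no step beyond the scatter is expected in this assay, and no direction is favoured. The starting point is compound 2 at 46%. The range stays wide, as the data hold no direct comparison. The expected change is a number 2 percentage points lower from compound 2 to compound 3 (within the scatter). For compound 3 the estimated value is 44%, with an expected range of 22% to 67%.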

Compound 3, percent of the compound remaining: 54%
Compound 3: the middle estimate sits 10 percentage points below what was measured; the range from low to high includes it.
By their numbers in this assay, from the lowest: compounds 2, 1 and 3 (each within the scatter of the next).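

Notes on the group on the carbonyl carbon: in this assay the exchange gives a number 8 percentage points higher from compound 2 to compound 3 (within the scatter) as the first measured step in the series at this position. The group with a five-membered aromatic ring with 2 hetero atoms and the group with a five-membered aromatic ring with 1 hetero atom therefore stand level in this read-out, so this single exchange on the carbonyl carbon, with the rest of compound 2 kept, moves the number by no more than repeated measurements would. No measurement is at hand that speaks to why the two groups read alike.

The compounds shown leave open whether the level reading holds for groups of a different kind on the same carbonyl carbon, such as an amine or a longer chain, since only this one pair differs in a single place. Also open, from the compounds shown here alone, is whether the same exchange behaves alike with another group on the sulfonyl, as the sulfonyl part of compound 1 has no partner that differs from it in one place alone.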